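Swapping chloro for methyl on the thiosemicarbazone aryl ring

The source may hold more compounds than are shown below. What is called first, only, known or untested is meant among the compounds shown, and "the series" means these compounds.

Compounds measured in a functional assay on CCRF-CEM cells (Homo sapiens), with a stated time of 72 h (on this read-out lower numbers stand for stronger inhibition and higher numbers for weaker inhibition), so far:
compound 1 `Cc1ccc(NC(=S)N/N=C2\C(=O)Nc3ccc(Br)cc32)cc1` gives 6800 nM;
compound 2 `Cc1ccc(NC(=S)N/N=C2\C(=O)N(Cc3ccc(F)cc3)c3ccc(F)cc32)cc1` gives 2500 nM;
compound 3 `O=C1/C(=N\NC(=S)Nc2ccc(Cl)cc2)c2cc(Br)ccc2N1Cc1ccc(F)cc1` gives 61000 nM.

Compound 3 stands highest of the three numbers, lying beyond the scatter above both compound 1 and compound 2. The next compound, compound 4 `Cc1ccc(NC(=S)N/N=C2\C(=O)N(Cc3ccc(F)cc3)c3ccc(Br)cc32)cc1`, is not yet measured in this assay. It differs from compound 3 in one place: methyl in place of chloro on an aromatic carbon, para to a large group. Compound 1 and compound 2 both carry the 4-methylphenyl and sit well below compound 3, so compound 4 is expected to move downward, by a step of roughly a 14-fold lower number from compound 3 to compound 4 (1.13 log units; beyond the scatter) in this assay. Compound 4 is thus estimated at 4500 nM, within a range from 1500 nM to 15000 nM.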

Compound 4, half-maximal inhibitory concentration: 132000 nM
For compound 4 the middle estimate is 29-fold (1.47 log units) below the measured one, and the stated range ends below it.
By their numbers in this assay, from the lowest: compound 2; then compound 1; then compound 3; then compound 4.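

In this assay, methyl in place of chloro on the aromatic carbon gives a 2.2-fold higher number from compound 3 to compound 4 (0.34 log units; beyond the scatter), so with this bromo and 4-fluorobenzyl substitution the 4-methylphenyl group offers no gain over the 4-chlorophenyl group. Much larger shifts come from the other single changes: bromo in place of fluoro gives a 53-fold higher number from compound 2 to compound 4 (1.72 log units; beyond the scatter), and 4-fluorobenzyl in place of the amide hydrogen gives a 19-fold higher number from compound 1 to compound 4 (1.29 log units; beyond the scatter). The methyl group therefore goes with both low and high numbers, depending on the rest of the molecule. The compounds shown leave open how a methoxy group or an amine would behave at this aryl position, and whether the bromo-to-fluoro step holds when the amide hydrogen is kept. Nothing measured here accounts for these steps.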